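The compounds below may be only part of what the source reports. "The series", "measured", "known", "first", "only" and "open" are said of these compounds alone.

Of the compounds shown here, three with a shared core have been measured in a functional assay on A549 cells (Homo sapiens) for antiproliferative activity, read by MTT assay, with a stated time of 48 h; on this read-out higher numbers stand for weaker inhibition and lower numbers for stronger inhibition. Compound 3 `Cc1ccc2[nH]c(-c3cn(-c4ccccc4)nc3-c3ccc(F)cc3)nc2c1` gives 1440 nM, and compound 2 `COc1ccc2[nH]c(-c3cn(-c4ccccc4)nc3-c3ccc(F)cc3)nc2c1` gives 1960 nM, so these two sit together at the low end of the numbers, within the scatter of each other. Compound 1 `FC(F)(F)c1ccc2[nH]c(-c3cn(-c4ccccc4)nc3-c3ccccc3)nc2c1` gives 5930 nM, a clearly higher number than compound 3 shows.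

The next compound is compound 4 `Fc1ccc(-c2nn(-c3ccccc3)cc2-c2nc3cc(C(F)(F)F)ccc3[nH]2)cc1`, where trifluoromethyl stands in place of methyl on an aromatic carbon (trifluoromethyl in place of methyl on an aromatic carbon). Among the measured compounds shown here, only one measured step swaps a single group in this way: methyl in place of methoxy on an aromatic carbon, a 1.4-fold lower number from compound 2 to compound 3 (0.13 log units; within the scatter). That step is small, but it involves a different group, so it offers only a weak guide.

The better clue is compound 1, which also carries trifluoromethyl and gives 5930 nM. It differs from compound 3 in a second place as well, so its value cannot be credited to trifluoromethyl alone. A moderate rise in the number is therefore expected in this assay, with an estimated 2.1-fold higher number from compound 3 to compound 4 (0.32 log units; beyond the scatter). For compound 4 the expected value is 3000 nM, with an estimated range from 1300 nM to 6500 nM.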

Compound 4, half-maximal inhibitory concentration: 2340 nM
Beside the measured number, compound 4's estimate is 1.3-fold (0.11 log units) above it; the measured number falls inside the stated range.
By their numbers in this assay, from the lowest: compounds 3, 2 and 4 (each within the scatter of the next); then compound 1.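

In this assay, trifluoromethyl in place of methyl on this aromatic carbon of the fused system gives a 1.6-fold higher number from compound 3 to compound 4 (0.21 log units; within the scatter), and trifluoromethyl in place of methoxy gives a 1.2-fold higher number from compound 2 to compound 4 (0.08 log units; within the scatter), so both swaps stay within the scatter even though trifluoromethyl brings 4 heavy atoms where methyl has 1. With trifluoromethyl held fixed, fluoro in place of hydrogen on an aromatic carbon gives a 2.5-fold lower number from compound 1 to compound 4 (0.40 log units; beyond the scatter), a modest step beyond the scatter, so the high number seen earlier goes with the missing fluoro and cannot be pinned on trifluoromethyl. No measurement is available that would explain why these numbers fall as they do.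

From the compounds shown here alone, only methyl, methoxy and trifluoromethyl appear at this position, so it remains open how an amine, a carboxylic acid or a longer chain would read there. Going by these compounds, it also remains open whether fluoro in place of hydrogen would produce a step of similar size alongside methyl or methoxy, as only the trifluoromethyl pair shows this change.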